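The compounds below may be only part of what the source reports. "The series", "measured", "known", "first", "only" and "open" are said of these compounds alone.

Three compounds sharing one core were measured in a functional assay on PC-3 cells (Homo sapiens) for inhibition, read by sulforhodamine B assay; on this read-out higher numbers stand for weaker inhibition of growth and lower numbers for stronger inhibition of growth. Compound 1 `Cc1ccccc1CN1CC=C(CCC(=O)NO)C1=O` gives 4620 nM. Compound 2 `CCOc1ccc(CCCN2CC=C(CCC(=O)NO)C2=O)cc1` gives 3480 nM, the second highest of the three numbers; its nearest neighbour is compound 1, and that gap lies within the scatter, as does its gap to compound 3, the furthest of the three. Compound 3 `CC(C)(C)c1ccc(CN2CC=C(CCC(=O)NO)C2=O)cc1` gives 1830 nM. Compound 4 `Cc1ccc(CCCN2CC=C(CCC(=O)NO)C2=O)cc1` differs from compound 2 in one place: methyl in place of ethoxy on an aromatic carbon. Among the compounds with values here, no two measured compounds differ in a single place, so nothing measured tells what this change does. Compound 4 is expected to stay within the scatter of compound 2, a step of a 1.1-fold lower number from compound 2 to compound 4 (0.04 log units; within the scatter). The estimate for compound 4 is 3200 nM, within a range from 1500 nM to 7000 nM.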

Compound 4, concentration for 50% growth inhibition: 3480 nM
Estimate against measurement, compound 4: 1.1-fold (0.04 log units) below, within the range that was stated.
By their numbers in this assay, from the lowest: compounds 3, 2, 4 and 1 (each within the scatter of the next, the first and the last beyond it).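

In this assay the exchange of ethoxy for methyl on an aromatic carbon, para to a large group, gives no change at the digits printed from compound 2 to compound 4 (within the scatter) and is the first single-place step among these compounds. At this position, then, the ethoxy group and its hydrogen-bond acceptor can give way to methyl with the number held. No available evidence says why the number holds.

On these data alone, it remains open whether an amine, a carboxylic acid or a longer alkoxy chain on this carbon would also leave the number in place. The compounds shown also leave open whether methyl for ethoxy would do the same with a different chain on the ring nitrogen of the shared core.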